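Adding hydroxy to the methyl of compound 2

The source may report more compounds than this note shows. Statements on the series, on what has been measured and on what is new or still open speak of the compounds shown alone.

In an in vitro ADME assay on microsomes from liver (Homo sapiens) for metabolic stability, with a stated time of 60 min, tested at 1 uM (a lower number here means slower removal, a higher number faster removal of the compound), compound 1 `COc1ccc(-c2cc(-c3ccc(S(C)(=O)=O)cc3)cnc2N)cn1` reads < 28 mL.min-1.g-1 as a limit and not a number. Compound 2 `Cc1ccc(-c2cc(-c3ccc(S(C)(=O)=O)cc3)cnc2N)cn1` reads < 5 mL.min-1.g-1 and this too is only a limit. Within the data shown here, the single measured step that the two limits leave unreadable from compound 1 to compound 2 offers no usable size. Among the measured compounds shown here, compound 3 `CS(=O)(=O)c1ccc(-c2cnc(N)c(-c3ccc(CO)nc3)c2)cc1` carries hydroxy in place of hydrogen on a saturated chain carbon bound to an aromatic carbon in a change of methyl to hydroxymethyl, and no measured step covers this change. The expectation therefore rests on compound 2 and its limit < 5 mL.min-1.g-1 alone. The estimated step of an at least 1.2-fold higher number from compound 2 to compound 3 (0.07 log units; that floor lies within the scatter) is small and expected to point toward faster removal. The estimate for compound 3 is 6 mL.min-1.g-1 with 2 mL.min-1.g-1 to 20 mL.min-1.g-1 as its expected range.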

Compound 3, intrinsic clearance in microsomes in the Homo sapiens assay: < 7 mL.min-1.g-1
Compound 3: no number, only a limit (the forecaster's own chance of this, stated with the estimate: 55%); the middle value does not contradict the limit.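

In the Homo sapiens assay compound 1 gives < 28 mL.min-1.g-1 as a limit and not a number. In the Homo sapiens assay compound 2 gives < 5 mL.min-1.g-1 as a limit and not a number. In the Homo sapiens assay compound 3 gives < 7 mL.min-1.g-1 as a limit and not a number. Among these compounds, no step among them can be read. As far as these compounds go, whether hydroxymethyl in place of methyl changes the intrinsic clearance in the Homo sapiens assay, and by how much, stays open. In a physicochemical assay for lipophilicity, read by HPLC, at pH 7.4 (on this read-out lower numbers stand for lower lipophilicity and higher numbers for higher lipophilicity), compound 2 gives 1.8 and compound 3 gives 1.2 as measured values, and the change is a number 0.60 log units lower from compound 2 to compound 3 (beyond the scatter) for hydroxymethyl in place of methyl.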